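This account rests on a few compounds, and the source may have more. Where it says the series, first, only, none or still open, it means among the compounds named here.

Working notes on the series. The shared core is held constant; the compounds differ in the group on the sulfonamide nitrogen. In a functional assay on HT-29 cells (Homo sapiens) for antiproliferative activity, read by sulforhodamine B assay, with a stated time of 48 h (a lower number here means a stronger inhibitor, a higher number a weaker inhibitor), compound 1 `COc1ccc(NS(=O)(=O)c2ccc(N3CCNC3=O)cc2)cc1` gives 800 nM, the highest of the three numbers measured. In this assay compound 2 `Cc1ccccc1NS(=O)(=O)c1ccc(N2CCNC2=O)cc1` gives 200 nM, and compound 3 `Cc1cccc(NS(=O)(=O)c2ccc(N3CCNC3=O)cc2)c1C` gives 190 nM. Both a 4.0-fold lower number from compound 1 to compound 2 (0.60 log units; beyond the scatter) and a 4.2-fold lower number from compound 1 to compound 3 (0.62 log units; beyond the scatter) lie beyond the scatter, whereas a 1.1-fold lower number from compound 2 to compound 3 (0.02 log units; within the scatter) lies within it.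

Compound 4 `CC(C)(C)c1ccc(NS(=O)(=O)c2ccc(N3CCNC3=O)cc2)cc1` differs from compound 1 by tert-butyl in place of methoxy on an aromatic carbon. Among the measured compounds shown here, no measured step exchanges one group for another at the position para to a large group; the two steps starting from compound 1 remove the methoxy and introduce methyl groups at other places on the ring, and each lowers the number modestly. They bear only indirectly on the change to compound 4, so the direction carries more weight than the size. In this assay a step of a 1.8-fold lower number from compound 1 to compound 4 (0.25 log units; within the scatter) is expected, toward a lower number, with wide uncertainty. Compound 4 is estimated at 450 nM, within 150 nM to 1500 nM.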

Compound 4, half-maximal inhibitory concentration: > 1000 nM
Compound 4 gave a limit, no number (the forecaster's own chance of this, stated with the estimate: 5%); at least 2.2-fold (0.34 log units) between middle value and limit.
By their numbers in this assay, from the lowest: compounds 3 and 2 (each within the scatter of the next); then compound 1. At a limit, above all of these: compound 4.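

In this assay compound 4 carries a limit and not a number: the limit of > 1000 nM in this assay, at which 1 of the 4 values shown sits. The only step shown at this place on the ring reads an at least 1.2-fold higher number from compound 1 to compound 4 (0.09 log units; that floor lies within the scatter), so tert-butyl in place of methoxy, para to a large group, does not show the lower number seen in the two steps from compound 1 to the methyl-bearing compounds, a 4.0-fold lower number from compound 1 to compound 2 (0.60 log units; beyond the scatter) and a 4.2-fold lower number from compound 1 to compound 3 (0.62 log units; beyond the scatter). On these data alone, as the floor of the new step lies within the scatter, its direction is suggested and not established, and its full size remains unknown.

As far as these compounds go, it remains open whether an amine or a hydroxyl group at this place would give a number lower than that of compound 1. A single exchange also cannot separate the departure of methoxy from the arrival of tert-butyl.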